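The compounds below may be only part of what the source reports. "The series", "measured", "known", "first", "only" and "open" are said of these compounds alone.

Measured compounds:
compound 1, `CC(C)(Oc1ccc(NCc2cccc(Oc3ccccc3)c2)cc1)C(=O)O`, 14%
compound 2, `CC(C)NC(=O)CCc1ccc(NCc2cccc(Oc3ccccc3)c2)cc1`, 66%

Among the compounds with values here, in a functional assay on CHO cells for agonist activity at Free fatty acid receptor 1 (Homo sapiens), read by a luciferase reporter (a lower number here means a smaller maximal response, a higher number a larger maximal response), compound 2 stands highest of the two numbers; its nearest neighbour is compound 1, and the only measured step, a number 52 percentage points higher from compound 1 to compound 2 (beyond the scatter), is large and beyond the scatter. Compound 3, `CC(C)NC(=O)[C@H]1C[C@@H]1c1ccc(NCc2cccc(Oc3ccccc3)c2)cc1`, differs from compound 2 by 2-(isopropylcarbamoyl)cyclopropyl in place of 2-(isopropylcarbamoyl)ethyl on an aromatic carbon. Within the data shown here, the one measured step does not bear directly on this change: it exchanged the whole side group, acid and ether for amide chain, whereas here the isopropylcarbamoyl amide is retained and only the two-carbon link to the ring is closed into a three-membered ring with two defined stereocentres. Among the measured compounds shown here, no measured pair shows what such a ring closure does in this assay, so the expectation rests on compound 2 alone, with wide uncertainty. A step of modest size in either direction is expected, and the estimate is placed close to compound 2, as a number 6 percentage points lower from compound 2 to compound 3 (within the scatter). For compound 3 the expected value in this assay is therefore 60%, with a range from 35% to 85%.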

Compound 3, largest response reached (reported as percent of maximum), in percent of the reference or control that the assay uses: 62%
Estimate against measurement, compound 3: 2 percentage points below, within the range that was stated.
By their numbers in this assay, from the lowest: compound 1; then compounds 3 and 2 (each within the scatter of the next).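

In this assay, 2-(isopropylcarbamoyl)cyclopropyl in place of 2-(isopropylcarbamoyl)ethyl, on the aromatic carbon para to a large group, gives a number 4 percentage points lower from compound 2 to compound 3 (within the scatter), so at this position the maximal response is kept with the three-membered ring and its 2 defined stereocentres, and the open chain is not needed for it. The large step away from 1-carboxy-1-methylethoxy also holds with the ring in place, as a number 48 percentage points higher from compound 1 to compound 3 (beyond the scatter) shows, so that step is now seen with two different links carrying the isopropylcarbamoyl group. Nothing available explains why the ring closure leaves the response where it stands.

The compounds shown leave open whether the response depends on the configuration of the cyclopropyl ring, since the opposite arrangement at its two stereocentres does not appear among them. They also do not separate the ether link of compound 1 from its acid: a carboxylic acid carried on the ethyl or cyclopropyl link, or a primary amide in place of the isopropyl amide, would show which part of the side group governs the maximal response.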